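Swapping a pyridinylmethyl ether for a piperidinyl ether

A few compounds are considered here, and "the series" means these few. Any claim that something is new, unique, unknown or untested is made for them only; others in the source may bear on it.

Among three measured analogues of one shared core, compound 2 `CC(=O)SCC(=O)c1ccc(NS(=O)(=O)c2ccc(OCc3ccccn3)cc2)nc1` gives the lowest number in a functional assay on HCT-116 cells (Homo sapiens) for cytotoxicity (a lower number here means that less compound is needed, a higher number that more compound is needed for the effect), at 420 nM. Compound 1 `CC(=O)SCC(=O)c1ccc(NS(=O)(=O)c2ccc(OC3CCCN(C)C3)cc2)nc1` gives 3700 nM in this assay, and compound 3 `COc1cccc(S(=O)(=O)Nc2ccc(C(=O)CSC(C)=O)cn2)c1` gives 4300 nM. Compound 4 `CC(=O)SCC(=O)c1ccc(NS(=O)(=O)c2ccc(OC3CCN(C)CC3)cc2)nc1` differs from compound 2 by 1-methylpiperidin-4-yl in place of (pyridin-2-yl)methyl on an oxygen on an aromatic ring. Among the compounds with values here, only one measured step bears on this change, and it runs the opposite way, from a 1-methylpiperidin-3-yl ether to the (pyridin-2-yl)methyl ether: an 8.8-fold lower number from compound 1 to compound 2 (0.94 log units; beyond the scatter). A return toward the number of compound 1 is therefore expected, and for compound 4 the estimated step is a 7.1-fold higher number from compound 2 to compound 4 (0.85 log units; beyond the scatter). Compound 4 is accordingly expected to give about 3000 nM in this assay, within a range of 1000 nM to 9000 nM.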

Compound 4, half-maximal effective concentration: 180 nM
The estimate for compound 4 lay 17-fold (1.22 log units) above the measured number; the whole stated range lies above it.
By their numbers in this assay, from the lowest: compound 4; then compound 2; then compounds 1 and 3 (each within the scatter of the next).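

In this assay this position on the oxygen proves sensitive to where the piperidine ring is attached, not only to whether one is present: 1-methylpiperidin-4-yl in place of 1-methylpiperidin-3-yl gives a 21-fold lower number from compound 1 to compound 4 (1.31 log units; beyond the scatter), the largest step shown. The non-aromatic 1-methylpiperidin-4-yl also outdoes the aromatic (pyridin-2-yl)methyl, with a 2.3-fold lower number from compound 2 to compound 4 (0.37 log units; beyond the scatter), so an aromatic ring here is not needed for the lowest number. Nothing available explains either step. Still open, on these data alone, is whether a piperidin-4-yl without the methyl, or a tetrahydropyran-4-yl with oxygen in place of the ring nitrogen, would keep this number.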